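Hydroxy for Fluoro on a Branched Chain Carbon

The source may report more compounds than this note shows. Statements on the series, on what has been measured and on what is new or still open speak of the compounds shown alone.

Compound 1, `COc1nc(=O)n(C)c(CC(F)(COC(C)=O)COC(C)=O)c1C`, carries a fluoro on a saturated chain carbon bound to three saturated chain carbons, flanked by two acetate esters. In an ADME assay on WI-38 cells (Homo sapiens) for antiproliferative activity, read by MTT assay, with a stated time of 72 h (on this read-out lower numbers stand for stronger inhibition and higher numbers for weaker inhibition), compound 1 gives only a limit, > 100000 nM. Two related compounds carry a hydroxy on that carbon instead. Compound 2, `COc1nc(=O)n(C)c(CC(O)(COCc2ccccc2)COCc2ccccc2)c1C`, which bears two benzyl ethers, gives 49800 nM in this assay. Compound 3, `COc1nc(=O)n(C)c(CC(O)(CO)CO)c1C`, which bears free hydroxyl groups, gives only a limit in this assay, > 100000 nM. Within the data shown here, compound 1 therefore stands at the limit of > 100000 nM in this assay, at which 2 of the 3 values shown sit, with compound 3 in the same position, while compound 2 is the one value that falls inside the measured range. Among the measured compounds shown here, no step between measured compounds that differ in a single place is available, so the pairs can only be read as they stand.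

Compound 4, `COc1nc(=O)n(C)c(CC(O)(COC(C)=O)COC(C)=O)c1C`, differs from compound 1 by hydroxy in place of fluoro on a saturated chain carbon bound to three saturated chain carbons. For the measured compounds named here, no measured pair in this assay isolates this exchange, and the hydroxy-bearing compounds 2 and 3 sit on either side of the limit. The expected step is a number no higher from compound 1 to compound 4 (the limit leaves the size open), none beyond the scatter. Compound 4 is estimated at 100000 nM, within 30000 nM to 300000 nM, with a fair chance that only a limit is reported again.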

Compound 4, half-maximal inhibitory concentration: > 100000 nM
Compound 4: no number, only a limit (the forecaster's own chance of this, stated with the estimate: 65%); the middle value sits exactly at the limit.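

Compound 1 and compound 4 each give only a limit in this assay, so no step can be read for hydroxy in place of fluoro on a saturated chain carbon bound to three saturated chain carbons. Compound 4 joins the compounds that stop at that limit: the limit of > 100000 nM in this assay, at which 3 of the 4 values shown sit.

The compounds shown leave open whether this exchange shifts antiproliferative activity at all, and in which direction.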